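Chain lengthening on two related cores against breast cancer cells

The compounds below may be only part of what the source reports. "The series", "measured", "known", "first", "only" and "open" are said of these compounds alone.

Compound 1 `CCCCCCCCCCCCCC/N=c1\nc(N)c2ncn(Cc3ccccc3)c2c(N)n1` and compound 2 `CCCCCCCC/N=c1\nc(N)c2ncn(Cc3ccccc3)c2c(N)n1` share a core and differ by hexyl in place of hydrogen on a saturated chain carbon, eight bonds along the chain from a double-bonded nitrogen. In a functional assay on MDA-MB-231 cells (Homo sapiens) for antiproliferative activity, read by WST assay, with a stated time of 72 h (on this read-out lower numbers stand for stronger inhibition and higher numbers for weaker inhibition), compound 2 gives 4750 nM, and compound 1 gives 5850 nM; the step is a 1.2-fold higher number from compound 2 to compound 1 (0.09 log units; within the scatter). Compound 3 `CC/N=c1\nc(N)c2nc[nH]c2c(N)n1` rests on a second core; the difference between the two cores is not broken down here. In this assay compound 3 was reported as "not active" (no number reported), with no number. Compound 4 `CCCCCCCC/N=c1\nc(N)c2nc[nH]c2c(N)n1` carries the same kind of change, hexyl entering on a saturated chain carbon, two bonds along the chain from a double-bonded nitrogen (hexyl in place of hydrogen on a saturated chain carbon, two bonds along the chain from a double-bonded nitrogen). Since compound 3 gave no number, and compound 2 reached only 4750 nM, compound 4 is expected to remain weak, estimated near 15000 nM in this assay, between 4000 nM and 60000 nM.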

Compound 4, half-maximal inhibitory concentration: "not active" (no number reported)
Compound 4: no number reported; the estimate stays without a comparison.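

In this assay compound 3 and compound 4 both stand without a number, so no step can be read between them. No supporting evidence bears on this result. The compounds shown leave open whether chain length changes activity on the core of compound 3.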